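Swapping Chloro for Dibutylamino on a Shared Core

The source may report more compounds than this note shows. Statements on the series, on what has been measured and on what is new or still open speak of the compounds shown alone.

Compound 1 `O=C(c1cc(Cc2n[nH]c(=O)c3ccccc23)ccc1F)N1CCc2nc(Cl)ncc2C1` carries a chloro group on its core. In a functional assay on MDA-MB-231 cells (Homo sapiens) for inhibition, read by MTT assay, with a stated time of 48 h (on this read-out lower numbers stand for stronger inhibition and higher numbers for weaker inhibition), compound 1 has no single number, and its entry reads "nd" (no result reported). Two related compounds carry amines at the same place. Compound 2 `O=C(c1cc(Cc2n[nH]c(=O)c3ccccc23)ccc1F)N1CCc2nc(N3CCCCC3)ncc2C1` gives only a limit in this assay, > 200000 nM. Compound 3 `CCCN(CCC)c1ncc2c(n1)CCN(C(=O)c1cc(Cc3n[nH]c(=O)c4ccccc34)ccc1F)C2` likewise gives only a limit, > 200000 nM. The step between them, a step that the two limits leave unreadable from compound 2 to compound 3, cannot be read, since both values are limits. Compound 4 `CCCCN(CCCC)c1ncc2c(n1)CCN(C(=O)c1cc(Cc3n[nH]c(=O)c4ccccc34)ccc1F)C2` differs from compound 1 by dibutylamino in place of chloro on an aromatic carbon. Among the measured compounds shown here, no measured step bears directly on this change, and the only guide is the limit of > 200000 nM in this assay, at which 2 of the 3 values shown sit, so neither direction nor size can be set in this assay. Compound 4 is therefore expected to sit near that same limit, estimated at 200000 nM with a range from 50000 nM to 600000 nM.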

Compound 4, half-maximal inhibitory concentration: > 200000 nM
Compound 4: a limit, no number; the forecaster's own chance of this, stated with the estimate: 80%; the middle value lies on the limit itself.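

Compound 2, compound 3 and compound 4 each give only a limit in this assay, so no new step can be read among them. The compounds shown leave open whether any amine at this place gives a readable number, and where compound 1 stands.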